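Swapping Chloro for Methyl: An Estimate for Compound 4

This account rests on a few compounds, and the source may have more. Where it says the series, first, only, none or still open, it means among the compounds named here.

Three compounds have been measured in a functional assay on HEK293 cells for antagonist activity at transient receptor potential cation channel subfamily V member 1 (Rattus norvegicus); on this read-out higher numbers stand for weaker inhibition and lower numbers for stronger inhibition:
compound 1 `Cc1ccc(NC(=O)N2CCN(c3ncccc3C(F)(F)F)CC2)cc1` gives 1550 nM;
compound 2 `CC(C)(C)c1ccc(NC(=O)N2CCN(c3ncccc3C(F)(F)F)CC2)cc1` gives 57.7 nM;
compound 3 `CC(C)c1ccc(NC(=O)N2CCN(c3ncccc3Cl)CC2)cc1` gives 17.3 nM.

Compound 3 stands lowest of the three in this assay; compound 2 is nearest and compound 1 furthest, both gaps beyond the scatter. Compound 4 `Cc1cccnc1N1CCN(C(=O)Nc2ccc(C(C)C)cc2)CC1` differs from compound 3 by methyl in place of chloro on an aromatic carbon. For the measured compounds named here, the only measured step, a 27-fold lower number from compound 1 to compound 2 (1.43 log units; beyond the scatter), concerns the other aromatic ring and does not bear on this change. Going by the values given here, compounds 2 and 3 differ in two places at once, so their values show only that compound 3 sits lower. Among the compounds with values here, no measured step involves the chloro group, so a modest step at most is expected in this assay: a 1.7-fold higher number from compound 3 to compound 4 (0.24 log units; within the scatter). Compound 4 is therefore estimated at 30 nM, with a range from 10 nM to 90 nM.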

Compound 4, half-maximal inhibitory concentration: 173 nM
Beside the measured number, compound 4's estimate is 5.8-fold (0.76 log units) below it, and the stated range ends below it.
By their numbers in this assay, from the lowest: compound 3; then compound 2; then compound 4; then compound 1.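

Methyl in place of chloro on an aromatic carbon, ortho to a large group, is not a neutral exchange in this assay: it gives a 10-fold higher number from compound 3 to compound 4 (1.00 log units; beyond the scatter). For the compounds shown here, this shows that the pyridine substituent, which no earlier step had touched, can itself shift the read-out, with chloro giving the stronger inhibition of the two. Nothing available accounts for the size of this step.

Going by these compounds, it remains open how an amine, a nitrile or a methoxy group would fare at this position. Also open, on these data alone, is whether the step would persist with tert-butyl in place of isopropyl on the other aromatic ring.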